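The source may report more compounds than this note shows. Statements on the series, on what has been measured and on what is new or still open speak of the compounds shown alone.

Measured in an ADME assay on L6 cells (Rattus norvegicus) for cytotoxicity, read by fluorescence and resazurin assay, with a stated time of 72 h; on this read-out lower numbers stand for higher toxicity in this test and higher numbers for lower toxicity in this test:
Compound 1 `Clc1ccc(-c2c[nH]cc2C(c2ccc(Cl)cc2Cl)n2ccnc2)cc1` gives 9610 nM.
Compound 2 `N#Cc1ccc(-c2c[nH]cc2C(c2ccc(Cl)cc2Cl)n2ccnc2)cc1` gives 15000 nM.
Compound 3 `Clc1ccc(C(c2c[nH]cc2-c2ccc(-c3ccccc3)cc2)n2ccnc2)c(Cl)c1` reaches only a limit of the assay, > 202000 nM.

Compound 2 holds the higher of the two numbers, with compound 1 nearest; the step of a 1.6-fold higher number from compound 1 to compound 2 (0.19 log units; within the scatter) stays within the scatter. Compound 4 `Clc1ccc(C(c2c[nH]cc2-c2ccc(-c3ccncc3)cc2)n2ccnc2)c(Cl)c1` differs from compound 2 by pyridin-4-yl in place of cyano on an aromatic carbon. The closest measured guide is the step of an at least 13-fold higher number from compound 2 to compound 3 (1.12 log units; beyond the scatter), and the parallel step an at least 21-fold higher number from compound 1 to compound 3 (1.32 log units; beyond the scatter) runs the same way; both end at the limit (the limit of > 202000 nM in this assay, at which 1 of the 3 values shown sits). A large upward step in this assay is therefore expected, with a fair chance that compound 4 also reaches only the limit. For compound 4 the estimate is 150000 nM, between 40000 nM and 300000 nM, an expected step of a 10-fold higher number from compound 2 to compound 4 (1.00 log units; beyond the scatter).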

Compound 4, half-maximal cytotoxic concentration: 15500 nM
Compound 4: the middle estimate sits 9.7-fold (0.99 log units) above what was measured; measured number below the stated range.
By their numbers in this assay, from the lowest: compounds 1, 2 and 4 (each within the scatter of the next). At a limit, above all of these: compound 3.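

At this position, on an aromatic carbon para to a large group, a second six-membered aromatic ring does not alone set the number in this assay: pyridin-4-yl gives a 1.0-fold higher number from compound 2 to compound 4 (0.01 log units; within the scatter) and a 1.6-fold higher number from compound 1 to compound 4 (0.21 log units; within the scatter). Among the compounds shown here, the one change from phenyl to pyridin-4-yl gives an at least 13-fold lower number from compound 3 to compound 4 (1.11 log units; beyond the scatter) and so separates two otherwise matched compounds. On these data alone, this step remains open-ended, as compound 3 stands at a limit: the limit of > 202000 nM in this assay, at which 1 of the 4 values shown sits.

As far as these compounds go, the effect of pyridin-3-yl, or of an aminomethyl or carboxylic acid on the terminal phenyl, remains open. From the compounds shown here alone, the true number for compound 3 also remains open.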